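Effect of an added methoxy group on cytotoxicity

A few compounds are considered here, and "the series" means these few. Any claim that something is new, unique, unknown or untested is made for them only; others in the source may bear on it.

Compound 1 `COc1ccc(-c2cc(/C=C/C(=O)c3ccc(N)cc3)[nH]n2)cc1` and compound 3 `COc1ccc(-c2cc(/C=C/C(=O)c3ccc(N)cc3)[nH]n2)cc1OC` share one core and differ in a single place: methoxy in place of hydrogen on an aromatic carbon. In a functional assay on MOLT-4 cells (Homo sapiens) for cytotoxicity, read by sulforhodamine B assay, with a stated time of 48 h, tested at 10 uM (on this read-out lower numbers stand for a stronger effect and higher numbers for a weaker effect at the one concentration tested), compound 1 gives -2% and compound 3 gives 6%; the step is a number 8 percentage points higher from compound 1 to compound 3 (within the scatter), so the two read-outs cannot be told apart.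

Compound 2 `COc1ccc(C(=O)/C=C/c2cc(-c3cc(OC)c(OC)c(OC)c3)n[nH]2)cc1OC` is built on a different core; the difference between the two cores is not broken down here. In this assay compound 2 gives -30%, the lowest of the three numbers, and its gaps to compound 1 and to compound 3 both lie beyond the scatter.

Compound 4 `COc1cc(C(=O)/C=C/c2cc(-c3cc(OC)c(OC)c(OC)c3)n[nH]2)cc(OC)c1OC` has not been measured. It differs from compound 2 in one place: methoxy in place of hydrogen on an aromatic carbon. This is the same kind of change as that between compound 1 and compound 3, though not the same: at the place in compound 4 the entering methoxy is also meta to a methoxy group, which the place in compound 3 does not have. Among the measured compounds shown here, the one measured instance of this change, a number 8 percentage points higher from compound 1 to compound 3 (within the scatter), stayed within the scatter. The expected step is therefore a number 2 percentage points higher from compound 2 to compound 4 (within the scatter), a small one, resting on that single prior step. Compound 4 is estimated at -28% in this assay, with a likely range from -45% to -10%. Whether the core of compound 2 carries this change in the same way cannot be settled from one earlier step.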

Compound 4, a percentage reported as activity, at one concentration (the size of the read-out at that concentration, not a potency): -4%
Compound 4: the middle estimate sits 24 percentage points below what was measured; the whole stated range lies below it.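

In this assay, methoxy in place of hydrogen on an aromatic carbon gives a number 26 percentage points higher from compound 2 to compound 4 (beyond the scatter), so on the core of compound 2 the added group goes with a weaker effect at the one concentration tested. The change therefore does not carry from one core to the other at a single size: the same change on two cores in this assay, a number 8 percentage points higher (within the scatter) from compound 1 to compound 3 and a number 26 percentage points higher (beyond the scatter) from compound 2 to compound 4, 18 percentage points apart, beyond the scatter of two such steps This does not show that the core alone sets the size of the step, since the pair comes from only two instances and the entering methoxy in compound 4 is also meta to a methoxy group, which the place in compound 3 does not have, so core and local surroundings cannot be separated here.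

The compounds shown leave open whether a group other than methoxy at this place, such as a hydroxyl or a carboxylic acid, would give a similar step on either core. They also leave open whether methoxy entering at a place with the same surroundings on both cores would give steps of matching size, and therefore how far any step from one core can serve as a guide for the other.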